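The source may report more compounds than this note shows. Statements on the series, on what has been measured and on what is new or still open speak of the compounds shown alone.

Notes on the series in a functional assay on the whole organism (strain Wistar) for inhibition, with Rattus norvegicus as the target, read by paw edema, with stated times of 30 min and 2.5 h, at a dose of 20 mg/kg by the intraperitoneal route; a higher number here means more inhibition at the dose given (going by the name of the read-out), a lower number less inhibition.

Compound 1, `CCc1nnc2sc(-c3c[nH]nc3-c3ccccc3)nn12`, gives 29.4% in this assay. Among the three measured compounds it stands below compound 3 and within the scatter of compound 2. Compound 2, `CCc1nnc2sc(-c3c[nH]nc3-c3ccc(F)cc3)nn12`, gives 23.5%; the step of a number 5.9 percentage points lower from compound 1 to compound 2 (within the scatter) is within the scatter, so the two cannot be ordered. Compound 3, `CCc1nnc2sc(-c3c[nH]nc3-c3ccc(Cl)cc3)nn12`, gives 56.9%; the step of a number 27.5 percentage points higher from compound 1 to compound 3 (beyond the scatter) is beyond the scatter, as is a number 33.4 percentage points higher from compound 2 to compound 3 (beyond the scatter).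

Compound 4, `CCCc1nnc2sc(-c3c[nH]nc3-c3ccccc3)nn12`, has not yet been measured. It differs from compound 1 by methyl in place of hydrogen on a saturated chain carbon, two bonds along the chain from an aromatic carbon. Among the compounds with values here, the three measured steps all concern a substituent on an aromatic carbon; none of them alters the saturated chain, so no measured step bears on this change. Within the data shown here, the chain carries no hydrogen-bond donors or acceptors and no charge in either compound. With nothing in the measured steps to point in either direction, the step of a number 0.4 percentage points lower from compound 1 to compound 4 (within the scatter) is expected to stay within the scatter. Compound 4 is therefore estimated at 29%, with a range from 14% to 44%.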

Compound 4, a percentage reported as inhibition, in the whole organism at one dose (the size of the read-out at that dose, not a potency): 56.9%
The estimate for compound 4 lay 27.9 percentage points below the measured number; measured number above the stated range.
By their numbers in this assay, from the lowest: compounds 2 and 1 (each within the scatter of the next); then compounds 3 and 4 (each within the scatter of the next).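

In this assay, the step of a number 27.5 percentage points higher from compound 1 to compound 4 (beyond the scatter) shows that the saturated chain is a position that responds: methyl in place of hydrogen, two bonds along the chain from an aromatic carbon, which turns ethyl into propyl, moves the read-out beyond the scatter. The earlier compounds shown here all carry the ethyl chain and speak only to a substituent on an aromatic carbon, where the step of a number 27.5 percentage points higher from compound 1 to compound 3 (beyond the scatter) lies beyond the scatter and the step of a number 5.9 percentage points lower from compound 1 to compound 2 (within the scatter) lies within it, so they gave no reading of the chain at all. Nothing available on these compounds accounts for the chain step.

Still open, on these data alone, is whether the response continues with a longer chain such as butyl, or depends on the shape of the chain, as a branched isopropyl or a ring-closed cyclopropyl would test. Also open, as far as these compounds go, is whether propyl and chloro add up when they stand on the same core, and whether a hydroxyl or an amine at the chain end is accepted in place of the terminal methyl.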